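Adding Fluorine to the Lowest Number Seen So Far

The compounds below may be only part of what the source reports. "The series", "measured", "known", "first", "only" and "open" are said of these compounds alone.

Of the compounds shown here, two have been tested in an assay on isolated protein for inhibition of lysine-specific demethylase 5A (Homo sapiens), read by AlphaLISA, with stated times of 15 min and 1 h, tested at 10 uM; on this read-out lower numbers stand for less inhibition and higher numbers for more inhibition at the one concentration tested (going by the name of the read-out). Compound 1 `O=C(O)c1ccnc(N/N=C/c2ccccc2)n1` gives 0% in this assay, while compound 2 `NNc1nccc(Oc2ccccc2)n1` gives -72%. Compound 2 therefore stands lowest of the two numbers, and its distance from compound 1 lies beyond the usual scatter. Compound 3 `NNc1nccc(Oc2ccc(F)cc2)n1` has not yet been measured. It differs from compound 2 in a single way: fluoro in place of hydrogen on an aromatic carbon. Within the data shown here, no step between measured compounds is known for this assay, so only a small shift, likely within the scatter, is expected. Compound 3 is estimated to give -55%, in a range from -95% to -5%. This corresponds to an expected step of a number 17 percentage points higher from compound 2 to compound 3 (beyond the scatter).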

Compound 3, a percentage reported as inhibition, at one concentration (the size of the read-out at that concentration, not a potency): -50%
For compound 3 the middle estimate is 5 percentage points below the measured one, and the stated range covers the measured number.
By their numbers in this assay, from the lowest: compound 2; then compound 3; then compound 1.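

In this assay, fluoro in place of hydrogen, on the carbon para to a group of 9 heavy atoms, gives a number 22 percentage points higher from compound 2 to compound 3 (beyond the scatter), so this position responds to the change of a single atom. The number for compound 3 is still negative, as it is for compound 2. Nothing available explains why the number moves.

Going by these compounds, whether chloro, methoxy or trifluoromethyl at this position would move the number in the same direction remains open. So does the effect of fluoro on another carbon of that ring.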